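Trimethoxyphenyl in place of phenyl on a longer-linker dienone

The compounds below may be only part of what the source reports. "The series", "measured", "known", "first", "only" and "open" are said of these compounds alone.

Measured compounds in a functional assay on HCT-116 cells (Homo sapiens) for inhibition, read by sulforhodamine B assay, with a stated time of 48 h, tested at 50 uM; on this read-out higher numbers stand for more inhibition of growth at the one concentration tested and lower numbers for less inhibition of growth:
Compound 1, `COc1cc(/C=C/C(=O)/C=C/c2cc(OC)c(OC)c(OC)c2)ccc1OCc1cn(CCOc2cc(=O)oc3ccccc23)nn1`, gives 89%.
Compound 2, `COc1cc(/C=C/C(=O)/C=C/c2ccccc2)ccc1OCc1cn(CCCCCOc2cc(=O)oc3ccccc23)nn1`, gives 24%.
Compound 3, `COc1cc(/C=C/C(=O)/C=C/c2ccccc2)ccc1OCc1cn(CCOc2cc(=O)oc3ccccc23)nn1`, gives 56%.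

Compounds 2 and 3 share most of their build, but the difference between their two cores is not broken down here. Among the three, compound 2 gives the lowest reading, and its steps to both others lie beyond the scatter.

Compound 3 turns into compound 1 by one change, (3,4,5-trimethoxyphenyl in place of phenyl on a double-bonded chain carbon bound to a double-bonded chain carbon). That step, a number 33 percentage points higher from compound 3 to compound 1 (beyond the scatter), is large and clear of the scatter.

Compound 4, `COc1cc(/C=C/C(=O)/C=C/c2cc(OC)c(OC)c(OC)c2)ccc1OCc1cn(CCCCCOc2cc(=O)oc3ccccc23)nn1`, has not yet been measured. It arises from compound 2 by 3,4,5-trimethoxyphenyl in place of phenyl on a double-bonded chain carbon bound to a double-bonded chain carbon, the same change made at the same place. Among the compounds with values here, from compound 2 to compound 4 a step of about a number 33 percentage points higher from compound 2 to compound 4 (beyond the scatter) is expected, resting on the single earlier example, a number 33 percentage points higher from compound 3 to compound 1 (beyond the scatter), and nothing more; with one example the spread must stay wide. Compound 4 is therefore estimated at 57%, plausibly between 35% and 78%.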

Compound 4, percent growth inhibition at one concentration: 53%
Compound 4: middle estimate off by 4 percentage points, on the high side; the range from low to high includes it.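

The change carried over to the second core: in this assay, 3,4,5-trimethoxyphenyl in place of phenyl gives a number 29 percentage points higher from compound 2 to compound 4 (beyond the scatter). The two steps have much the same size, so in these two pairs the swap added a similar amount to the growth inhibition, whichever core carried it: the same change on two cores in this assay, a number 33 percentage points higher (beyond the scatter) from compound 3 to compound 1 and a number 29 percentage points higher (beyond the scatter) from compound 2 to compound 4, 4 percentage points apart, within the scatter of two such steps This does not make it a rule for the series, since two pairs are a small sample, each compound was read at only one concentration, and nothing here explains why the swap raises the reading.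

The swap also left the two cores apart, with compound 1 at 89% and compound 4 at 53%, so it adds to what each core gives rather than levelling them. Still open, on these data alone, is whether a phenyl ring carrying a single methoxy group, a chlorine or a dimethylamino group would give a similar rise, and whether the same step would hold on cores with other chain lengths in the linker.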